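The source may hold more compounds than are shown below. What is called first, only, known or untested is meant among the compounds shown, and "the series" means these compounds.

Of the compounds shown here, three have so far been measured in a functional assay on HCT-8 cells (Homo sapiens) for cytotoxicity, read by MTT assay, with a stated time of 48 h; on this read-out lower numbers stand for stronger inhibition and higher numbers for weaker inhibition. Compound 1 `CN1CCN(c2ccc(Nc3ncc(F)c(NC4CCCC4)n3)cc2)CC1` gives 29000 nM, the highest of the three numbers. For the measured compounds named here, compound 2 `COc1cc(C(=O)NC2CCN(C)CC2)ccc1Nc1ncc(Br)c(NC2CCCC2)n1` gives 12000 nM, and compound 3 `COc1cc(C(=O)NC2CCN(C)CC2)ccc1Nc1ncc(Cl)c(NC2CCCC2)n1` gives 4400 nM; the only single-point step among them, a 2.7-fold lower number from compound 2 to compound 3 (0.44 log units; beyond the scatter), concerns a halogen on the core and not the amine side chain. Compound 4 `CCCNc1nc(Nc2ccc(N3CCN(C)CC3)cc2)ncc1F` differs from compound 1 by propyl in place of cyclopentyl on a nitrogen on an aromatic ring: the cyclopentyl, a five-membered non-aromatic ring of carbon only, gives way to a propyl chain with no ring. Going by the values given here, no measured step touches this position, so the expectation rests on compound 1 alone. Compound 4 is expected to move by a 1.4-fold higher number from compound 1 to compound 4 (0.14 log units; within the scatter), a small weakening that may not exceed the scatter. Compound 4 is therefore estimated at 40000 nM, within 12000 nM to 130000 nM.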

Compound 4, half-maximal inhibitory concentration: 50000 nM
Compound 4: middle estimate off by 1.3-fold (0.10 log units), on the low side; measured number inside the range.
By their numbers in this assay, from the lowest: compound 3; then compound 2; then compounds 1 and 4 (each within the scatter of the next).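

In this assay the data show a 1.7-fold higher number from compound 1 to compound 4 (0.24 log units; within the scatter) with propyl in place of cyclopentyl, so on this nitrogen an open chain stands in for the ring without a change beyond the scatter. The ring is thus not shown to be needed for this number in this series. Nothing at hand offers a reason for this result. Still open, from the compounds shown here alone, is whether a larger ring such as cyclohexyl, or a chain ending in an amine or a carboxylic acid, would move the number beyond the scatter. Going by these compounds, whether the same swap behaves alike on the core of compound 3 also remains open.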